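Ring swap on the piperidine nitrogen of compound 3

This account rests on a few compounds, and the source may have more. Where it says the series, first, only, none or still open, it means among the compounds named here.

Compound 3 `COc1cnc(N2CCC(CCCNc3ccc4c(c3)OCC4=O)CC2)nc1` gives the lowest number among the three measured compounds in a functional assay on CHO-K1 cells for agonist activity at Glucose-dependent insulinotropic receptor (Mus musculus), read by HTRF and cAMP accumulation, with a stated time of 30 min (on this read-out lower numbers stand for an effect already at smaller amounts and higher numbers for an effect only at larger amounts of compound), with a value of 60 nM; compound 1 `CC(C)(C)OC(=O)N1CCC(CCCNc2ccc3c(c2)C(=O)CC3)CC1` gives 123 nM and compound 2 `CCc1cnc(N2CCC(CCCNc3ccc4c(c3)OCC4=O)CC2)nc1` gives 159 nM. Within the data shown here, the one step comparable in scope, a 2.7-fold lower number from compound 2 to compound 3 (0.42 log units; beyond the scatter), shows that a change of the substituent on the aromatic ring moves the number by a modest amount. Compound 4 `CC(C)c1nnc(N2CCC(CCCNc3ccc4c(c3)OCC4=O)CC2)o1` carries 5-isopropyl-1,3,4-oxadiazol-2-yl in place of 5-methoxypyrimidin-2-yl on an amine nitrogen in a ring. Among the measured compounds shown here, no measured step replaces this ring itself, so the direction is uncertain; the isopropyl group is closer in kind to the ethyl of compound 2 than to the methoxy of compound 3, so a modest rise in this assay is expected, as a 2.0-fold higher number from compound 3 to compound 4 (0.30 log units; within the scatter). Compound 4 is therefore estimated at 120 nM, within a range of 40 nM to 400 nM.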

Compound 4, half-maximal effective concentration: 1020 nM
Compound 4: the middle estimate sits 8.5-fold (0.93 log units) below what was measured; measured number above the stated range.
By their numbers in this assay, from the lowest: compound 3; then compounds 1 and 2 (each within the scatter of the next); then compound 4.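

Replacing 5-methoxypyrimidin-2-yl with 5-isopropyl-1,3,4-oxadiazol-2-yl on an amine nitrogen in a ring gives, in this assay, a 17-fold higher number from compound 3 to compound 4 (1.23 log units; beyond the scatter), and replacing the ethyl-bearing pyrimidine gives a 6.4-fold higher number from compound 2 to compound 4 (0.81 log units; beyond the scatter). Heavy-atom make-up, donor count and acceptor count stay the same across the first swap, so these counts alone do not set the number at this position. No evidence on the cause of this rise is at hand.

On these data alone, whether the rise follows the five-membered ring or the isopropyl group remains open. A 5-methoxy-1,3,4-oxadiazol-2-yl group would separate the two.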